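A smaller, single-fluorine ring on the sulfur linker

A few compounds are considered here, and "the series" means these few. Any claim that something is new, unique, unknown or untested is made for them only; others in the source may bear on it.

Compound 3 `Nc1cc(N)c2nc(-c3ccccc3)c(Sc3ccc(Cl)c(Cl)c3)nc2c1` stands at the lower of the two readable numbers in a functional assay on U-251 cells (Homo sapiens) for inhibition, read by sulforhodamine B assay, with a stated time of 48 h (on this read-out lower numbers stand for stronger inhibition of growth and higher numbers for weaker inhibition of growth), where compound 3 gives 10200 nM. Compound 1 `Nc1cc(N)c2nc(-c3ccccc3)c(Oc3ccc(Cl)c(Cl)c3)nc2c1` gives 12000 nM in this assay, and the step of a 1.2-fold lower number from compound 1 to compound 3 (0.07 log units; within the scatter) is within the scatter. Compound 2 `COc1ccc(Sc2nc3cc(N)cc(N)c3nc2-c2ccccc2)cc1` reaches only a limit of this assay, < 100000 nM, as recorded in the limit of < 100000 nM in this assay, at which 1 of the 3 values shown sits. For that reason a step that the limit leaves unreadable from compound 1 to compound 2 and a step that the limit leaves unreadable from compound 2 to compound 3 are unreadable. Compound 4 `Nc1cc(N)c2nc(-c3ccccc3)c(Sc3ccc(F)cc3)nc2c1` differs from compound 3 by 4-fluorophenyl in place of 3,4-dichlorophenyl on a sulfur. Within the data shown here, no measured step covers this exchange; the unreadable steps show only that changing the ring on the sulfur can push the number beyond reach. The expected step of a 2.0-fold higher number from compound 3 to compound 4 (0.29 log units; within the scatter) is therefore a weakening of uncertain size. Compound 4 is estimated at 20000 nM, within 5000 nM to 80000 nM.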

Compound 4, concentration for 50% growth inhibition: 16200 nM
For compound 4 the middle estimate is 1.2-fold (0.09 log units) above the measured one, within the range that was stated.
By their numbers in this assay, from the lowest: compounds 3, 1 and 4 (each within the scatter of the next).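

In this assay, a ring change on this sulfur now gives a readable step: a 1.6-fold higher number from compound 3 to compound 4 (0.20 log units; within the scatter). Set against the oxygen-linked compound, the result is a 1.4-fold higher number from compound 1 to compound 4 (0.13 log units; within the scatter), so 4-fluorophenyl and 3,4-dichlorophenyl cannot be told apart here, even with one chlorine-bearing ring swapped for a smaller ring. The step from compound 2 to compound 4 cannot be read, as the value of compound 2 is a limit: the limit of < 100000 nM in this assay, at which 1 of the 4 values shown sits.

From the compounds shown here alone, it remains open whether an amine or a carboxylic acid on the ring on the sulfur would move the number beyond the scatter.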